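Working notes: the nitrile step to compound 3

The source may hold more compounds than are shown below. What is called first, only, known or untested is meant among the compounds shown, and "the series" means these compounds.

Of the compounds shown here, two frame the series so far. In an in vivo functional assay on the whole organism (plasma, strain Sprague-Dawley) for pharmacokinetics, with Rattus norvegicus as the target, at a dose of 1 mg/kg (on this read-out higher numbers stand for fast clearance and lower numbers for slow clearance), compound 1 (`CC(C)(O)c1ccn2c(-c3ccc(F)c(-c4cccnc4)c3)cnc2n1`) gives 9.1 mL/min/kg. Compound 2 (`CC(C)(O)c1cnn2c(-c3ccc(F)c(-c4ncc(F)cc4F)c3)cnc2n1`) gives 1.2 mL/min/kg, the lower of the two numbers, and the gap between them lies beyond the scatter. These two compounds differ in more than one place, so their gap does not isolate any single change.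

Compound 3 (`CC(C)(O)c1cnn2c(-c3ccc(F)c(-c4ncccc4C#N)c3)cnc2n1`) carries 3-cyanopyridin-2-yl in place of 3,5-difluoropyridin-2-yl on an aromatic carbon, ortho to a fluoro group: 3-cyanopyridin-2-yl in place of 3,5-difluoropyridin-2-yl on an aromatic carbon. For the measured compounds named here, no measured pair covers this change, so the expectation is tentative. A small rise in this assay is expected, a 1.7-fold higher number from compound 2 to compound 3 (0.22 log units; within the scatter), which would stay within the scatter. The estimate for compound 3 is 2 mL/min/kg, with an expected range of 0.9 mL/min/kg to 6 mL/min/kg.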

Compound 3, clearance: 2.4 mL/min/kg
Compound 3: middle estimate off by 1.2-fold (0.08 log units), on the low side, within the range that was stated.
By their numbers in this assay, from the lowest: compounds 2 and 3 (each within the scatter of the next); then compound 1.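

For the compounds shown here, exchanging 3,5-difluoropyridin-2-yl for 3-cyanopyridin-2-yl on this aromatic carbon, ortho to a fluoro group, gives the first single-place step in this assay, with a 2.0-fold higher number from compound 2 to compound 3 (0.30 log units; within the scatter) as its size. At this position, then, the nitrile-bearing ring and the difluorinated ring cannot be told apart on this read-out, and the low clearance of compound 2 does not depend on keeping both fluorines. No accompanying measurement bears on this result, so the step stands as an observation without an explanation.

From the compounds shown here alone, whether a carboxamide or an aminomethyl group on the same pyridine ring would also stay within the scatter of compound 2 remains open. Also open, going by these compounds, is whether this exchange gives a similar step on the core of compound 1.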